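The source may hold more compounds than are shown below. What is called first, only, known or untested is meant among the compounds shown, and "the series" means these compounds.

Working notes on the series. Compound 1 `CC1(C)[C@H]2CC[C@]1(C)N(Cc1cn(-c3ccccc3C#N)nn1)C(=O)C2` gives 110 nM in a functional assay on OVCAR-3 cells (Homo sapiens) for inhibition, read by MTT assay, with a stated time of 24 h; a higher number here means a weaker inhibitor, a lower number a stronger inhibitor. Compound 2 `CC1(C)[C@H]2CC[C@]1(C)N(Cc1cn(-c3ccccc3Cl)nn1)C(=O)C2` gives 40 nM and compound 3 `COc1cccc(-n2cc(CN3C(=O)C[C@@H]4CC[C@@]3(C)C4(C)C)nn2)c1` gives 280 nM. Compound 2 stands lowest of the three: the step of a 2.8-fold lower number from compound 1 to compound 2 (0.44 log units; beyond the scatter) and the step of a 7.0-fold higher number from compound 2 to compound 3 (0.85 log units; beyond the scatter) both lie beyond the scatter, so compound 2 is the strongest inhibitor of the measured set, with compound 1 nearest and compound 3 furthest.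

Compound 4 `COc1ccc(-n2cc(CN3C(=O)C[C@@H]4CC[C@@]3(C)C4(C)C)nn2)cc1` is not yet measured. It differs from compound 2 as follows: 4-methoxyphenyl in place of 2-chlorophenyl on an aromatic nitrogen.

The measured steps that bear on this are the step of a 7.0-fold higher number from compound 2 to compound 3 (0.85 log units; beyond the scatter), where a methoxyphenyl group replaced the 2-chlorophenyl on the same aromatic nitrogen, and the step of a 2.5-fold higher number from compound 1 to compound 3 (0.41 log units; beyond the scatter). Both moves to a methoxyphenyl raised the number. Among the measured compounds shown here, no measured pair shows how 4-methoxyphenyl compares with 3-methoxyphenyl, so that part of the change is unanchored.

Compound 4 is therefore expected to give a higher number than compound 2, with a step of roughly a 6.3-fold higher number from compound 2 to compound 4 (0.80 log units; beyond the scatter), because of a 7.0-fold higher number from compound 2 to compound 3 (0.85 log units; beyond the scatter). The estimate for compound 4 is 250 nM, with a range from 80 nM to 800 nM.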

Compound 4, half-maximal inhibitory concentration: 250 nM
Estimate against measurement, compound 4: no gap at the digits printed, within the range that was stated.
By their numbers in this assay, from the lowest: compound 2; then compound 1; then compounds 4 and 3 (each within the scatter of the next).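

Among the compounds shown here, the place of the methoxy group on the phenyl ring gives no readable difference in this assay (a 1.1-fold lower number from compound 3 to compound 4 (0.05 log units; within the scatter)), a comparison the earlier compounds could not offer. The 4-methoxyphenyl group therefore joins the 3-methoxyphenyl group in giving a higher number than the 2-chlorophenyl group (a 6.3-fold higher number from compound 2 to compound 4 (0.80 log units; beyond the scatter)) and the 2-cyanophenyl group (a 2.3-fold higher number from compound 1 to compound 4 (0.36 log units; beyond the scatter)), so for these two methoxyphenyl groups the result does not depend on that place. No measurement of any property of these groups is available to explain these steps.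

Left open is how a phenyl ring carrying an amine or a carboxylic acid in this assay would stand against the 2-chlorophenyl group of compound 2. Also open is whether a chloro group elsewhere on the phenyl ring keeps the low number, since the compounds shown carry it only as 2-chlorophenyl.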